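Benzoyl in place of carbamoyl on the shared core

The compounds below may be only part of what the source reports. "The series", "measured", "known", "first", "only" and "open" are said of these compounds alone.

Measured compounds:
- compound 1 `N#C/C(=C\N1CCN(C(=O)c2ccco2)C1=S)C(=O)Nc1ccc(Cl)cc1`: 20600 nM
- compound 2 `N#C/C(=C\N1CCN(C(=O)c2ccco2)C1=S)C(N)=O`: 43600 nM

In a functional assay on OVCAR-8 cells (Homo sapiens) for inhibition, read by sulforhodamine B assay, with a stated time of 48 h (on this read-out lower numbers stand for stronger inhibition of growth and higher numbers for weaker inhibition of growth), compound 2 gives 43600 nM, the higher of the two numbers recorded so far. Going by the values given here, its only neighbour in the set is compound 1, which in this assay gives 20600 nM; the step of a 2.1-fold higher number from compound 1 to compound 2 (0.33 log units; beyond the scatter) is modest but beyond the scatter.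

The next compound to be run is compound 3 `N#C/C(=C\N1CCN(C(=O)c2ccco2)C1=S)C(=O)c1ccccc1`. Relative to compound 2 the change is phenyl in place of amino on a carbonyl carbon; cut one bond further out it reads carbamoyl to benzoyl.

Among the compounds with values here, only one measured step touches this change. The step of a 2.1-fold higher number from compound 1 to compound 2 (0.33 log units; beyond the scatter) shows that removing an aryl group from the amide end of the side chain raised the number modestly. Within the data shown here, compound 3 puts an aryl group back at the same end of the chain, though on the carbonyl carbon rather than on a nitrogen, and no measured pair reports that exact swap. A modest move in the lower direction is therefore expected, of about a 1.7-fold lower number from compound 2 to compound 3 (0.24 log units; within the scatter), with wide uncertainty.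

For compound 3 in this assay the estimate is 25000 nM, within the range 8000 nM to 75000 nM.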

Compound 3, concentration for 50% growth inhibition: 25400 nM
Compound 3: the middle estimate sits 1.0-fold (0.01 log units) below what was measured; measured number inside the range.
By their numbers in this assay, from the lowest: compounds 1, 3 and 2 (each within the scatter of the next, the first and the last beyond it).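

In this assay, phenyl in place of amino on a carbonyl carbon gives a 1.7-fold lower number from compound 2 to compound 3 (0.23 log units; within the scatter), so this change, unlike the earlier removal of the 4-chlorophenyl group, does not separate its two compounds beyond the scatter. The other new comparison, a 1.2-fold higher number from compound 1 to compound 3 (0.09 log units; within the scatter), also stays within the scatter, so phenyl and (4-chlorophenyl)amino on this carbonyl carbon cannot be told apart here, even though they differ in the nitrogen and the chlorine; only the earlier step, a 2.1-fold higher number from compound 1 to compound 2 (0.33 log units; beyond the scatter), separates two compounds of the set beyond the scatter. No supporting data bear on this result, and the three values alone offer no explanation for it.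

Still open, from the compounds shown here alone, is how a 4-chlorobenzoyl or phenylcarbamoyl group on the shared core would compare, which would help show whether the chlorine or the amide nitrogen matters on its own. A small alkyl group such as methyl, or a carboxylic acid, on the same carbonyl carbon would test whether any aromatic ring is needed there at all.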